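The compounds below may be only part of what the source reports. "The series", "measured", "known", "first", "only" and "open" are said of these compounds alone.

Measured so far:
compound 1, `Cc1nc(N)sc1CCCN/C(N)=N/C(=O)N[C@H](C)c1ccccc1`: 0.34
compound 2, `N/C(=N\C(=O)NCc1ccccc1)NC1CCc2nc(N)sc2C1`: 0.31

In a functional assay on HEK293T cells for agonist activity at histamine H2 receptor (Homo sapiens), read by beta-arrestin recruitment (a lower number here means a smaller maximal response, a higher number a larger maximal response), compound 1 gives 0.34. In this assay compound 2 gives 0.31, a number that lies within the usual scatter of the value of compound 1, so the two cannot be told apart on these data. Going by the values given here, no pair of measured compounds differing in a single place has been recorded, and therefore no measured step is known on which a change of configuration could be judged.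

Compound 3, `Cc1nc(N)sc1CCCN/C(N)=N/C(=O)N[C@@H](C)c1ccccc1`, is the compound not yet measured. It is related to compound 1 as follows: the two compounds have the same atoms and bonds and differ only in configuration as drawn: 1 of 2 stereo elements differ; a stereocentre at a saturated chain carbon is drawn R in compound 1 and S in compound 3. The numbers of compound 1 and compound 2 sit close together. Among the compounds with values here, the only guide to the size of such a step is the scatter itself. A small change, in either direction, is expected, with nothing beyond the scatter anticipated. The expected step a number 0.040 lower from compound 1 to compound 3 (within the scatter) is small and slightly downward. Compound 3 is estimated to reach 0.3 in this assay, with a range from 0.14 to 0.5.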

Compound 3, intrinsic activity: the largest response reached, as a fraction of the reference agonist's: 0.46
Estimate against measurement, compound 3: 0.16 below; low and high end bracket the measured number.
By their numbers in this assay, from the lowest: compounds 2 and 1 (each within the scatter of the next); then compound 3.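

Going by these compounds alone, the pair gives the first measured step, and it shows that configuration alone can move the maximal response. In this assay, changing the stereocentre at the saturated chain carbon from R to S gives a number 0.12 higher from compound 1 to compound 3 (beyond the scatter), so this position is sensitive to how its groups are arranged in space, and not only to which groups are present. The step can be assigned to this one stereocentre, and to no other part of the structure, because of a single fact: the fact that compounds 1 and 3 differ only in the configuration as drawn.

What the compounds shown leave open is whether the S configuration would keep its advantage, and a step of similar size, with an ethyl group in place of the group now at the stereocentre, or with a longer chain in the rest of the structure. This is a single pair, so it establishes no general preference for S, and it gives no reason why this configuration reaches the larger maximal response.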